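The compounds below may be only part of what the source reports. "The series", "measured", "known", "first", "only" and "open" are said of these compounds alone.

Measured in a functional assay on HepG2 cells (Homo sapiens) for inhibition, read by MTT assay, with a stated time of 48 h; a lower number here means a stronger inhibitor, a higher number a weaker inhibitor:
- compound 1 `CS(=O)(=O)Nc1ccc(-n2cc(COc3ccccc3Cl)nn2)cc1Oc1ccccc1`: 25300 nM
- compound 2 `Cc1cc(OCc2cn(-c3ccc(NS(C)(=O)=O)c(Oc4ccccc4)c3)nn2)ccc1Cl`: 9800 nM

Going by the values given here, of these two compounds, compound 2 has the lower number in this assay, and compound 1 is its only neighbour. Compound 3 `CS(=O)(=O)Nc1ccc(-n2cc(COc3ccc4ccccc4c3)nn2)cc1Oc1ccccc1` has not yet been measured. It carries naphthalen-2-yl in place of 4-chloro-3-methylphenyl on an oxygen on a saturated carbon. Among the compounds with values here, only one measured step bears on this change. It lies at the same place, where 4-chloro-3-methylphenyl replaced 2-chlorophenyl, and it was modest: a 2.6-fold lower number from compound 1 to compound 2 (0.41 log units; beyond the scatter). That single step gives a rough idea of size, but it says nothing firm about direction for a naphthalen-2-yl group. A step no larger than that one is therefore expected, and the estimated outcome is a 1.2-fold lower number from compound 2 to compound 3 (0.09 log units; within the scatter). For compound 3 the expected value is 8000 nM, with an estimated range from 3000 nM to 22000 nM.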

Compound 3, half-maximal inhibitory concentration: 19500 nM
For compound 3 the middle estimate is 2.4-fold (0.39 log units) below the measured one; the range from low to high includes it.
By their numbers in this assay, from the lowest: compounds 2, 3 and 1 (each within the scatter of the next, the first and the last beyond it).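

In this assay the exchange of 4-chloro-3-methylphenyl for naphthalen-2-yl gives a 2.0-fold higher number from compound 2 to compound 3 (0.30 log units; within the scatter) and the exchange of 2-chlorophenyl for naphthalen-2-yl gives a 1.3-fold lower number from compound 1 to compound 3 (0.11 log units; within the scatter) so compound 3 cannot be told apart from either neighbour. The earlier compounds shown here showed only chlorine-bearing aryl groups at this place, whereas compound 3 shows that a group with two six-membered aromatic rings and no chlorine still gives a number within the scatter of both. Nothing available accounts for this result.

On these data alone, whether an amine, a carboxylic acid or a longer chain on this oxygen would move the number beyond the scatter remains open. Also open, as far as these compounds go, is whether the chlorine or the methyl group of compound 2 accounts for its gap from compound 1.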